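Methyl to trifluoromethyl on the pendant aryl ring

The source may hold more compounds than are shown below. What is called first, only, known or untested is meant among the compounds shown, and "the series" means these compounds.

Measured compounds:
compound 1, `Cc1ccc(-c2c(C3=NN(C(=O)CCC(=O)O)C(c4ccc(Cl)cc4)C3)c(=O)[nH]c3ccccc23)cc1`: 1400 nM
compound 2, `O=C(O)CCC(=O)N1N=C(c2c(-c3ccc(C(F)(F)F)cc3)c3ccccc3[nH]c2=O)CC1c1ccc(Cl)cc1`: 2800 nM
compound 3, `Cc1cccc(-c2c(C3=NN(C(=O)CCC(=O)O)C(c4ccc(Cl)cc4)C3)c(=O)[nH]c3ccccc23)c1`: 1900 nM

All values come from an assay on cells (Oocyte) for negative allosteric modulation of glutamate receptor ionotropic, NMDA 2D (Rattus norvegicus), read by two-electrode voltage clamp; a lower number here means a stronger inhibitor, a higher number a weaker inhibitor. Compound 3 stands second highest of the three numbers; its gaps to compound 1 and to compound 2 are both within the scatter, so no order among the three is claimed. Compound 4, `O=C(O)CCC(=O)N1N=C(c2c(-c3cccc(C(F)(F)F)c3)c3ccccc3[nH]c2=O)CC1c1ccc(Cl)cc1`, carries trifluoromethyl in place of methyl on an aromatic carbon. Going by the values given here, the one measured step of the same kind is a 2.0-fold higher number from compound 1 to compound 2 (0.30 log units; within the scatter), which stayed within the scatter. A step of similar size and direction, still within the scatter, is expected here. Compound 4 is therefore expected to move by a 1.8-fold higher number from compound 3 to compound 4 (0.27 log units; within the scatter). Compound 4 is estimated at 3500 nM, with a range of 1500 nM to 8000 nM.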

Compound 4, half-maximal inhibitory concentration: 2600 nM
The estimate for compound 4 lay 1.3-fold (0.13 log units) above the measured number, within the range that was stated.
By their numbers in this assay, from the lowest: compounds 1, 3, 4 and 2 (each within the scatter of the next).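

In this assay, trifluoromethyl in place of methyl now also reads on the 3-substituted ring, with a 1.4-fold higher number from compound 3 to compound 4 (0.14 log units; within the scatter), and the two matched steps agree: the same change on two cores in this assay, a 2.0-fold higher number (0.30 log units; within the scatter) from compound 1 to compound 2 and a 1.4-fold higher number (0.14 log units; within the scatter) from compound 3 to compound 4, 1.5-fold (0.16 log units) apart, within the scatter of two such steps. Changing 4-(trifluoromethyl)phenyl to 3-(trifluoromethyl)phenyl gives a 1.1-fold lower number from compound 2 to compound 4 (0.03 log units; within the scatter), and changing 4-methylphenyl to 3-(trifluoromethyl)phenyl gives a 1.9-fold higher number from compound 1 to compound 4 (0.27 log units; within the scatter). Neither the group nor its place on this ring separates these four compounds beyond the scatter.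

As far as these compounds go, whether an amine or a carboxylic acid on this ring would give a step beyond the scatter remains open.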